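Swapping Methoxy for Chloro on the Benzyl Ring

A few compounds are considered here, and "the series" means these few. Any claim that something is new, unique, unknown or untested is made for them only; others in the source may bear on it.

Compound 1 `COc1ccc(N2C(=O)N(Cc3c(F)cc(F)cc3OC)c3ccccc3S2(=O)=O)cc1OC` gives an inhibition constant of 6.31 nM in an assay on HEK293 cells for displacement of a labelled ligand from Orexin receptor type 2 (Homo sapiens), read by scintillation counting, with a stated time of 90 min; a higher number here means a weaker inhibitor, a lower number a stronger inhibitor. Among the three measured compounds it holds the second highest number: compound 3 `COc1cc(N2C(=O)N(Cc3c(F)cc(F)cc3F)c3ccccc3S2(=O)=O)ccn1` gives 63.1 nM, a weaker inhibitor, while compound 2 `COc1cc(F)c(CN2C(=O)N(c3cc(OC)nc(OC)c3)S(=O)(=O)c3ccccc32)c(F)c1` gives 0.251 nM, a much stronger one. Compound 4 `COc1ccc(N2C(=O)N(Cc3c(F)cc(F)cc3Cl)c3ccccc3S2(=O)=O)cc1OC` differs from compound 1 by a single substitution, (chloro in place of methoxy on an aromatic carbon). For the measured compounds named here, no pair of measured compounds differs in only one place, so there is no measured step to lean on here. The change is expected to leave the number close to that of compound 1, with an expected step of a 1.3-fold lower number from compound 1 to compound 4 (0.10 log units; within the scatter) that need not reach beyond the scatter. Compound 4 is therefore estimated at 5 nM, within a range from 1.5 nM to 20 nM.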

Compound 4, inhibition constant: 1 nM
Beside the measured number, compound 4's estimate is 5.0-fold (0.70 log units) above it; measured number below the stated range.
By their numbers in this assay, from the lowest: compound 2; then compound 4; then compound 1; then compound 3.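

Going from 2,4-difluoro-6-methoxybenzyl to 2-chloro-4,6-difluorobenzyl, with the rest of the molecule unchanged, gives a 6.3-fold lower number from compound 1 to compound 4 (0.80 log units; beyond the scatter) in this assay, so this position on the benzyl ring can shift the number beyond the usual scatter. The entering chloro has fewer heavy atoms than the methoxy and no hydrogen-bond acceptor, but these counts alone do not show which difference matters. No measurement here explains the step. As far as these compounds go, it remains open whether a methyl, a bromo or an amine in this place would give a number nearer that of the chloro or the methoxy.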